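The source may hold more compounds than are shown below. What is called first, only, known or untested is meant among the compounds shown, and "the series" means these compounds.

In an ADME assay on CEM-SS cells (Homo sapiens) for cytotoxicity, read by XTT assay, with a stated time of 6 days (a lower number here means that less compound is tolerated, a higher number that more compound is tolerated), the measured compounds give these values:
- compound 1 `CCCC(=O)OCSc1ccccc1C(=O)NCCCCC(N)=O` gives 51.7 uM
- compound 2 `CCCC(=O)OCSc1ccccc1C(=O)NCCCCNC(C)=O` gives 17.4 uM
- compound 3 `CCCC(=O)OCSc1ccccc1C(=O)NCCCCCNC(C)=O` gives 9.2 uM

Compound 3 shares the low end of these numbers with compound 2, as their gap lies within the scatter (a 1.9-fold lower number from compound 2 to compound 3 (0.28 log units; within the scatter)). It stands clearly apart from compound 1 (a 5.6-fold lower number from compound 1 to compound 3 (0.75 log units; beyond the scatter)).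

Compound 4 `CCCC(=O)OCSc1ccccc1C(=O)NCC(=O)OC` is not yet measured. It carries methoxycarbonyl in place of 4-acetamidobutyl (methoxycarbonyl in place of 4-acetamidobutyl on a saturated chain carbon bound to an amide-type nitrogen). Going by the values given here, no measured step makes this change, so the only guide is the size of the other steps, which were modest (a 3.0-fold lower number from compound 1 to compound 2 (0.47 log units; beyond the scatter)). With compound 3 at the low end, the direction is uncertain. A modest rise is expected (a 2.7-fold higher number from compound 3 to compound 4 (0.43 log units; beyond the scatter)). Compound 4 is estimated at 25 uM (range 8 uM to 80 uM).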

Compound 4, half-maximal toxic concentration: 27.3 uM
Estimate against measurement, compound 4: 1.1-fold (0.04 log units) below; the range from low to high includes it.
By their numbers in this assay, from the lowest: compounds 3, 2, 4 and 1 (each within the scatter of the next, the first and the last beyond it).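

In this assay, the much smaller methoxycarbonyl on a saturated chain carbon bound to an amide-type nitrogen gives a 3.0-fold higher number from compound 3 to compound 4 (0.47 log units; beyond the scatter), so a long chain is not needed here for the number to stay in this range. Measured against the other two chains, the same kind of change gives a 1.6-fold higher number from compound 2 to compound 4 (0.20 log units; within the scatter) and a 1.9-fold lower number from compound 1 to compound 4 (0.28 log units; within the scatter), so compound 4 cannot be told apart from either. No measurement available here explains these steps. As far as these compounds go, what a carboxylic acid or an amine in place of methoxycarbonyl would give in this assay remains open.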